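Swapping fluoro for bromo on compound 3

A few compounds are considered here, and "the series" means these few. Any claim that something is new, unique, unknown or untested is made for them only; others in the source may bear on it.

Compound 1 `COc1ccccc1Oc1c(N)nc(-c2cccc(Br)c2)nc1Cl` gives 24600 nM in the series.
Compound 2 `COc1cccc(-c2nc(N)c(Oc3ccccc3OC)c(OCCO)n2)c1` gives 30500 nM in the series.
Compound 3 `COc1ccccc1Oc1c(N)nc(-c2cccc(F)c2)nc1OCCO` gives 20900 nM in the series.

All three values come from a functional assay on B16 cells (Mus musculus) for cytotoxicity, read by CCK-8 assay, with a stated time of 24 h (a lower number here means a stronger inhibitor, a higher number a weaker inhibitor), and lie within the scatter of one another. Compound 3 (20900 nM) is therefore not separated from compound 1 or compound 2 by any real margin.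

The next compound, compound 4 `COc1ccccc1Oc1c(N)nc(-c2cccc(Br)c2)nc1OCCO`, has not yet been measured. It differs from compound 3 by one exchange, bromo in place of fluoro on an aromatic carbon.

Two pieces of evidence bear on this exchange. Going by the values given here, the only measured step at such a carbon is a 1.5-fold lower number from compound 2 to compound 3 (0.16 log units; within the scatter), where fluoro replaces methoxy, and it stays within the scatter. In addition, compound 1 already carries the 3-bromophenyl group and gives 24600 nM, although it differs from compound 4 at another place on the core. Among the compounds with values here, no measured pair isolates the exchange of fluoro for bromo itself.

In this assay no step beyond the scatter is therefore expected. The estimated step is a 1.1-fold higher number from compound 3 to compound 4 (0.02 log units; within the scatter), which is small. For compound 4 the estimated value is 22000 nM, with an expected range from 12000 nM to 38000 nM in all likelihood.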

Compound 4, half-maximal inhibitory concentration: 21900 nM
For compound 4 the middle estimate is 1.0-fold (0.00 log units) above the measured one; measured number inside the range.
By their numbers in this assay, from the lowest: compounds 3, 4, 1 and 2 (each within the scatter of the next).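

In this assay, the exchange of 3-fluorophenyl to 3-bromophenyl now has a measured pair of its own: a 1.0-fold higher number from compound 3 to compound 4 (0.02 log units; within the scatter), and with methoxy at the same aromatic carbon the comparison reads a 1.4-fold lower number from compound 2 to compound 4 (0.14 log units; within the scatter), so fluoro, bromo and methoxy at this place are not told apart by this read-out. The other place on the shared core, with the 3-bromophenyl group held constant, also gives no separation, since 2-hydroxyethoxy in place of chloro reads a 1.1-fold lower number from compound 1 to compound 4 (0.05 log units; within the scatter). Nothing available explains why these exchanges leave the numbers within the scatter of one another.

From the compounds shown here alone, all four compounds thus stay within the scatter, and it remains open whether any group at either place can move the number in this assay beyond it. An amine or a carboxylic acid on the aromatic carbon that carries the bromo, plain hydrogen at that carbon, or a longer chain in place of 2-hydroxyethoxy are not among the compounds shown, so their effect on this cytotoxicity remains unknown.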